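Replacing Benzylamino with Chloro: A Small Expected Step

A few compounds are considered here, and "the series" means these few. Any claim that something is new, unique, unknown or untested is made for them only; others in the source may bear on it.

Measured so far:
Compound 1, `OC[C@H]1O[C@@H](n2cnc3c(NCc4ccccc4)nccc32)C[C@@H]1O`: 8%
Compound 2, `[O-][n+]1ccc2c(c1)ncn2[C@H]1C[C@H](O)[C@@H](CO)O1`: < 5%
Compound 3, `OC[C@H]1OC(n2cnc3c(Nc4ccccc4)nccc32)[C@H](O)[C@@H]1O`: 10%

All three were tested in a functional assay on EL4 cells (Mus musculus) for inhibition, tested at 100 uM; on this read-out higher numbers stand for more inhibition at the one concentration tested (going by the name of the read-out) and lower numbers for less inhibition. Compound 1 gives 8% in this assay, the lower of the two plain numbers reported. Compound 3 gives 10%, and since the gap to compound 1 lies within the usual scatter, the two cannot be ordered against each other. For compound 2 the assay reports only a limit, < 5%. This is the limit of < 5% in this assay, at which 1 of the 3 values shown sits.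

Compound 4, `OC[C@H]1O[C@@H](n2cnc3c(Cl)nccc32)C[C@@H]1O`, has not yet been measured in this assay. It differs from compound 1 in a single place: chloro in place of benzylamino on an aromatic carbon. The change leaves the sugar part and the fused two-ring core untouched and exchanges the benzylamino substituent for a chloro.

Within the data shown here, no step between measured compounds is available to lean on, so the expectation rests on how little room the measured values occupy. The step of a number 3 percentage points lower from compound 1 to compound 4 (within the scatter) is expected to be small, not beyond the scatter, and if anything slightly downward toward the limit. Compound 4 is therefore estimated at 5%, with a plausible range from 0% to 15%.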

Compound 4, a percentage reported as inhibition, at one concentration (the size of the read-out at that concentration, not a potency): < 5%
Compound 4 gave a limit, no number (the forecaster's own chance of this, stated with the estimate: 40%); the middle value lies on the limit itself.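

In this assay, among these compounds, the exchange of benzylamino for chloro on an aromatic carbon, next to the ring nitrogen, gives the first step that can be read at this position: a number at least 3 percentage points lower from compound 1 to compound 4 (that floor lies within the scatter). The step shows that replacing benzylamino, with its six-membered aromatic ring, by a single chlorine brings no gain in inhibition at the one concentration tested, but it cannot show how far inhibition really falls, and it therefore leaves open whether the change exceeds the scatter. Compound 4 gives < 5%, which is a limit of the assay and not a number, and with it a second compound in this small set has no exact value: the limit of < 5% in this assay, at which 2 of the 4 values shown sit.

The compounds shown leave open whether a plain amine, a methoxy group or a longer chain in this place on the shared core would lift inhibition clear of the limit, or leave it just as low. Compound 3 differs from compound 1 in more than one place, so what its anilino-type substituent contributes on its own also remains unresolved.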